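Aryl change on the amide-type nitrogen of compound 1

The source may report more compounds than this note shows. Statements on the series, on what has been measured and on what is new or still open speak of the compounds shown alone.

Measured in a functional assay on HL-60 cells (Homo sapiens) for inhibition, read by CCK-8 assay, with a stated time of 48 h; on this read-out higher numbers stand for weaker inhibition and lower numbers for stronger inhibition:
- compound 1 `Cc1cc(C)cc(NC(=O)NCCNS(=O)(=O)c2ccc(-c3ccccc3Oc3ccc([N+](=O)[O-])c([N+](=O)[O-])c3)s2)c1`: 9100 nM
- compound 2 `Cc1cc(C)cc(NC(=O)NCCNS(=O)(=O)c2ccc(-c3ccccc3OCc3ccccc3)s2)c1`: 2200 nM

Compound 1 holds the higher of the two numbers. Compound 3 `O=C(NCCNS(=O)(=O)c1ccc(-c2ccccc2Oc2ccc([N+](=O)[O-])c([N+](=O)[O-])c2)s1)Nc1ccc(Cl)cc1` carries 4-chlorophenyl in place of 3,5-dimethylphenyl on an amide-type nitrogen. Among the measured compounds shown here, the only measured step, a 4.1-fold lower number from compound 1 to compound 2 (0.62 log units; beyond the scatter), changes a different place, so it shows a size that one change can reach but gives no direction here. No measurement covers this place, so no step beyond the scatter is expected in this assay. The expected change is a 1.1-fold lower number from compound 1 to compound 3 (0.06 log units; within the scatter). Compound 3 is estimated at 8000 nM, with an expected range of 3000 nM to 22000 nM.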

Compound 3, half-maximal inhibitory concentration: 8100 nM
Compound 3: middle estimate off by 1.0-fold (0.01 log units), on the low side; the measured number falls inside the stated range.
By their numbers in this assay, from the lowest: compound 2; then compounds 3 and 1 (each within the scatter of the next).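

In this assay, 4-chlorophenyl in place of 3,5-dimethylphenyl on the amide-type nitrogen gives a 1.1-fold lower number from compound 1 to compound 3 (0.05 log units; within the scatter), so this one aryl swap at this position, on the core of compound 1, leaves the read-out within the scatter. Neither the two methyl groups nor the chlorine separates these two compounds here. No supporting evidence bears on this result. Still open, going by these compounds, is whether a non-aryl group on this nitrogen, such as a cyclohexyl ring or a chain ending in a carboxylic acid, would move the number. Also open, on these data alone, is whether 4-chlorophenyl behaves the same way alongside the benzyl group of compound 2.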